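A Second Look at a Trifluoromethoxy Swap

A few compounds are considered here, and "the series" means these few. Any claim that something is new, unique, unknown or untested is made for them only; others in the source may bear on it.

Of the compounds shown here, three have been measured in an assay on isolated protein for inhibition of DNA topoisomerase 1 (Homo sapiens), with a stated time of 30 min, tested at 100 uM; a lower number here means a weaker effect, a higher number a stronger effect of the compound at the concentration tested. Compound 1 `Cc1ccc2c(=O)[nH]c(-c3ccccc3OC(F)(F)F)nc2c1` gives 100% in this assay. Compound 2 `Cc1ccc2c(=O)[nH]c(-c3ccccc3F)nc2c1` gives 81.2% in this assay, and compound 3 `Cc1ccc2nc(-c3ccccc3F)[nH]c(=O)c2c1` gives 67.9% in this assay, the lowest of the three numbers.

Compound 1 and compound 2 differ in one place only, (trifluoromethoxy in place of fluoro on an aromatic carbon); this change made a step of a number 18.8 percentage points higher from compound 2 to compound 1 (beyond the scatter) in this assay. Compound 2 and compound 3 contain the same atoms joined differently, and the difference between the two cores is not broken down here.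

Compound 4 `Cc1ccc2nc(-c3ccccc3OC(F)(F)F)[nH]c(=O)c2c1` has not been measured. It stands to compound 3 as compound 1 stands to compound 2: trifluoromethoxy in place of fluoro on an aromatic carbon, and the surroundings of the change are the same in both pairs, so this is the same change made on the other core.

A step of about the earlier size, a number 17.1 percentage points higher from compound 3 to compound 4 (beyond the scatter), is expected for compound 4, because compound 3 starts from 67.9% and the same change gave a number 18.8 percentage points higher from compound 2 to compound 1 (beyond the scatter). Compound 4 is therefore estimated at 85%, between 68% and 98%, in this assay.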

Compound 4, a percentage reported as inhibition, at one concentration (the size of the read-out at that concentration, not a potency): 66.9%
Compound 4: the middle estimate sits 18.1 percentage points above what was measured; the whole stated range lies above it.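

On the core of compound 3, placing trifluoromethoxy where fluoro stood gives a number 1 percentage points lower from compound 3 to compound 4 (within the scatter) in this assay, so the gain seen on the core of compound 1 does not appear here. The two cores therefore respond differently to the same change, and a step measured on one of them could not safely be copied to the other in this series: the same change on two cores in this assay, a number 18.8 percentage points higher (beyond the scatter) from compound 2 to compound 1 and a number 1 percentage points lower (within the scatter) from compound 3 to compound 4, 19.8 percentage points apart, beyond the scatter of two such steps. For the compounds shown here, this rests on only two matched pairs, each read at a single concentration, so it does not show why the cores part ways, whether the effects would compare in the same way at other concentrations, or whether any other change would also depend on the core.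

The compounds shown carry only fluoro and trifluoromethoxy at this place on the aromatic ring, so it remains open whether methoxy, chloro or an amine would also behave differently on the two cores. They also leave open whether replacing the methyl group with a longer chain would give the same step on both cores.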